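Aryl variation on the hydrazone carbon of the shared core

The compounds below may be only part of what the source reports. "The series", "measured", "known", "first", "only" and "open" are said of these compounds alone.

Compound 3 `COc1cc2c(Oc3ccc(NC(=O)N/N=C/c4ccc(O)cc4)cc3F)ccnc2cc1OCCCN1CCCCC1` stands second highest of the three numbers in a functional assay on MKN-45 cells (Homo sapiens) for cytotoxicity, read by MTT assay, with a stated time of 72 h (a lower number here means a stronger inhibitor, a higher number a weaker inhibitor), where compound 3 gives 850 nM. Compound 1 `COc1cc2c(Oc3ccc(NC(=O)N/N=C/c4ccc(F)cc4Cl)cc3F)ccnc2cc1OCCCN1CCCCC1` gives 270 nM and compound 2 `COc1ccc(/C=N/NC(=O)Nc2ccc(Oc3ccnc4cc(OCCCN5CCCCC5)c(OC)cc34)c(F)c2)c(OC)c1` gives 1990 nM. Compound 4 `COc1cc2c(Oc3ccc(NC(=O)N/N=C/c4ccncc4)cc3F)ccnc2cc1OCCCN1CCCCC1` carries pyridin-4-yl in place of 4-hydroxyphenyl on a carbon with a double bond to nitrogen. Going by the values given here, the steps that bear on this change all vary the same ring: a 3.1-fold higher number from compound 1 to compound 3 (0.50 log units; beyond the scatter), a 7.4-fold higher number from compound 1 to compound 2 (0.87 log units; beyond the scatter) and a 2.3-fold lower number from compound 2 to compound 3 (0.37 log units; beyond the scatter). Each was modest, and none of the three measured rings resembles a pyridin-4-yl, so only the spread among them guides the expectation. For compound 4 a step within that spread is expected, a 1.2-fold higher number from compound 3 to compound 4 (0.07 log units; within the scatter), with no clear direction. For compound 4 the estimate in this assay is 1000 nM, with a range from 300 nM to 3500 nM.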

Compound 4, half-maximal inhibitory concentration: 980 nM
Estimate against measurement, compound 4: 1.0-fold (0.01 log units) above; the measured number falls inside the stated range.
By their numbers in this assay, from the lowest: compound 1; then compounds 3 and 4 (each within the scatter of the next); then compound 2.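

In this assay, pyridin-4-yl on the carbon with a double bond to nitrogen matches 4-hydroxyphenyl (a 1.2-fold higher number from compound 3 to compound 4 (0.06 log units; within the scatter)), so giving up the hydrogen-bond donor counted for that ring leaves the number within the scatter. The pyridin-4-yl compound keeps modest gaps to the other two rings (a 2.0-fold lower number from compound 2 to compound 4 (0.31 log units; beyond the scatter)) and (a 3.6-fold higher number from compound 1 to compound 4 (0.56 log units; beyond the scatter)), so a ring with a hetero atom does not close the gap to 2-chloro-4-fluorophenyl. No measured evidence accompanies these steps.

Still open, as far as these compounds go, is whether a 4-aminophenyl or 4-carboxyphenyl ring at this place would differ from compound 4. A pyridin-3-yl ring is equally untested here.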